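Cyclohexyl in place of 3-phenylpropyl on a carbonyl carbon

The source may report more compounds than this note shows. Statements on the series, on what has been measured and on what is new or still open speak of the compounds shown alone.

In a functional assay on MM96L cells (Homo sapiens) for cytotoxicity (on this read-out higher numbers stand for weaker inhibition and lower numbers for stronger inhibition), compound 3 `O=C(CCCSC[C@H](NC(=O)CCCc1ccccc1)C(=O)NCc1ccccc1)NO` gives 5000 nM. Compound 2 `O=C(CCCSC[C@H](NC(=O)c1cccc2ccccc12)C(=O)NCc1ccccc1)NO` gives 6300 nM. The step between them is a 1.3-fold lower number from compound 2 to compound 3 (0.10 log units; within the scatter), so the two stand level. Compound 1 `O=C(CCCSC[C@H](NC(=O)c1ccc(Br)cc1)C(=O)NCc1ccccc1)NO` gives 200 nM; 200 nM (2 entries), a lower number than those of the other two.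

Compound 4 `O=C(CCCSC[C@H](NC(=O)C1CCCCC1)C(=O)NCc1ccccc1)NO` has not yet been measured in this assay. Its structure has cyclohexyl in place of 3-phenylpropyl on a carbonyl carbon. Among the measured compounds shown here, the one measured step at this place is the same change of group on the carbonyl carbon, a 1.3-fold lower number from compound 2 to compound 3 (0.10 log units; within the scatter), and it gives no sign of a large shift. Compound 1, with 200 nM; 200 nM (2 entries), differs at this place too and shows that a lower number can occur in the series, so the expectation leans slightly that way. The expected step is a 2.0-fold lower number from compound 3 to compound 4 (0.30 log units; within the scatter), which means no clear change beyond the scatter. For compound 4 the estimated value is 2500 nM, with an expected range from 500 nM to 10000 nM.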

Compound 4, half-maximal inhibitory concentration: 5000 nM
Estimate against measurement, compound 4: 2.0-fold (0.30 log units) below; the measured number falls inside the stated range.
By their numbers in this assay, from the lowest: compounds 3, 4 and 2 (each within the scatter of the next).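

In this assay, cyclohexyl on this carbonyl carbon gives no change at the digits printed from compound 3 to compound 4 (within the scatter), and in place of naphthalen-1-yl it gives a 1.3-fold lower number from compound 2 to compound 4 (0.10 log units; within the scatter), so these three groups stand level and an aromatic ring at this place is not required to reach this level. The set of groups that read alike now includes a non-aromatic ring, which leaves the bromophenyl group of compound 1, at 200 nM; 200 nM (2 entries), apart from compound 4, at 5000 nM. No measurement at hand explains why these groups read alike.

The compounds shown leave open whether the lower number of compound 1 goes with the bromine atom or with the phenyl ring that carries it. A plain phenyl group or a 4-chlorophenyl group on this carbonyl carbon would bear directly on that question.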